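Hydroxy in place of chloro: expectation for compound 3

This account rests on a few compounds, and the source may have more. Where it says the series, first, only, none or still open, it means among the compounds named here.

Of the compounds shown here, two on the shared core have numbers so far. In a functional assay on MCF7 cells (Homo sapiens) for antiproliferative activity, read by MTT assay, with a stated time of 72 h (on this read-out higher numbers stand for weaker inhibition and lower numbers for stronger inhibition), compound 1 `COc1ccccc1-c1ccc2ncn(-c3cc(OC)c(OC)c(OC)c3)c2c1` gives 1750 nM and compound 2 `COc1cc(-n2cnc3ccc(-c4cccc(Cl)c4)cc32)cc(OC)c1OC` gives 3120 nM on this read-out, which places compound 2 within the scatter of compound 1. Compound 3 `COc1cc(-n2cnc3ccc(-c4cccc(O)c4)cc32)cc(OC)c1OC` differs from compound 2 by hydroxy in place of chloro on an aromatic carbon, meta to a large group (hydroxy in place of chloro on an aromatic carbon). Within the data shown here, one measured step bears on this place: 3-chlorophenyl stands in place of 2-methoxyphenyl (a 1.8-fold higher number from compound 1 to compound 2 (0.25 log units; within the scatter)) and the step stays within the scatter. Hydroxy appears in no measured compound, so the data set no direction for the change. The expected step (a 1.6-fold lower number from compound 2 to compound 3 (0.19 log units; within the scatter)) therefore stays within the scatter. In this assay compound 3 is estimated at 2000 nM with an expected range from 500 nM to 6000 nM for a measurement.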

Compound 3, half-maximal inhibitory concentration: 350 nM
Estimate against measurement, compound 3: 5.7-fold (0.76 log units) above; measured number below the stated range.
By their numbers in this assay, from the lowest: compound 3; then compounds 1 and 2 (each within the scatter of the next).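

In this assay the two earlier compounds stood within the scatter of each other, so this position had shown no clear response to a change of group. Hydroxy in place of chloro now gives an 8.9-fold lower number from compound 2 to compound 3 (0.95 log units; beyond the scatter), and 3-hydroxyphenyl in place of 2-methoxyphenyl gives a 5.0-fold lower number from compound 1 to compound 3 (0.70 log units; beyond the scatter), so the position does respond, and the exchange of a single heavy atom is enough to show it. No supporting measurement accompanies these steps, and the reason for the lower number stays unexplained.

Open, going by these compounds, is whether an amine or a carboxylic acid at this place would give a number like that of compound 3, or whether the step belongs to hydroxy alone. Also open, on these data alone, is whether hydroxy on another carbon of this ring would keep the lower number.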